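Compound 4: Methyl in Place of Fluoro on the Aromatic Carbon

This account rests on a few compounds, and the source may have more. Where it says the series, first, only, none or still open, it means among the compounds named here.

Of the compounds shown here, three sharing one core have been measured in an assay on MDA-MB-231 cells for binding affinity to C-X-C chemokine receptor type 4 (Homo sapiens), read by immunofluorescence and microscopy, with stated times of 10 min and 30 min; on this read-out lower numbers stand for an effect already at smaller amounts and higher numbers for an effect only at larger amounts of compound. Compound 1 `Cc1ccc(S(=O)(=O)NCc2ccc(CNC(=O)c3ccc(Cl)cc3)cc2)cc1` gives 10 nM in this assay, and compound 2 `Cc1ccc(S(=O)(=O)NCc2ccc(CNC(=O)c3c(Cl)cc(Cl)cc3Cl)cc2)cc1` gives 10 nM. Compound 3 `Cc1ccc(S(=O)(=O)NCc2ccc(CNC(=O)c3ccccc3F)cc2)cc1` gives 1000 nM, the highest of the three numbers. The step of no change at the digits printed from compound 1 to compound 2 (within the scatter) lies within the scatter, whereas a 100-fold higher number from compound 1 to compound 3 (2.00 log units; beyond the scatter) and a 100-fold higher number from compound 2 to compound 3 (2.00 log units; beyond the scatter) are both large and beyond it.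

Compound 4 `Cc1ccc(S(=O)(=O)NCc2ccc(CNC(=O)c3ccccc3C)cc2)cc1` differs from compound 3 by methyl in place of fluoro on an aromatic carbon. Among the measured compounds shown here, no measured pair shows fluoro exchanged for methyl, so the two large steps onto compound 3 are the only guide. For the measured compounds named here, they show that the 2-fluorophenyl compound stands far from compound 1 and compound 2 in this assay, and compound 4 keeps a group on that same aromatic carbon, ortho to a large group, while swapping only the one heavy atom. On that basis the step of no change at the digits printed from compound 3 to compound 4 (within the scatter) is expected to stay within the scatter, with no clear direction. Compound 4 is therefore estimated at 1000 nM in this assay, with a range from 300 nM to 3000 nM. This estimate rests on compound 3 and its value of 1000 nM, the nearest measured point in structure.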

Compound 4, effective concentration (reported as EC, without a stated level of effect): 100 nM
For compound 4 the middle estimate is 10-fold (1.00 log units) above the measured one; measured number outside the range, below it.
By their numbers in this assay, from the lowest: compounds 1 and 2 (each within the scatter of the next); then compound 4; then compound 3.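

In this assay, exchanging one heavy atom on this aromatic carbon, ortho to a large group, clearly registers: methyl in place of fluoro gives a 10-fold lower number from compound 3 to compound 4 (1.00 log units; beyond the scatter). This recovers only part of the gap opened by the 2-fluorophenyl compound, since the 2-methylphenyl group still leaves a 10-fold higher number from compound 1 to compound 4 (1.00 log units; beyond the scatter) and a 10-fold higher number from compound 2 to compound 4 (1.00 log units; beyond the scatter). The group on this single carbon therefore matters in this series, and compound 4 takes an intermediate place instead of matching either compound 3 or the two chlorine-bearing compounds, although nothing available here accounts for the difference between methyl and fluoro.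

The compounds shown leave open how a methoxy group, an amine or a carboxylic acid on this same aromatic carbon would read in this assay. Also open, as far as these compounds go, is whether a lone chloro on this carbon, without the other chloro groups of the 2,4,6-trichlorophenyl compound, would stand closer to compound 4 or to compound 2.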